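A few compounds are considered here, and "the series" means these few. Any claim that something is new, unique, unknown or untested is made for them only; others in the source may bear on it.

Measured so far:
- compound 1 `COc1cc(-c2cc(C(=O)/C=C/c3ccc(Cl)cc3)nc3cc(-c4ccccc4)nn23)cc(OC)c1OC`: 19500 nM
- compound 2 `COc1cc(-c2cc(/C=C/C(=O)c3ccc(Cl)cc3)nc3cc(-c4ccccc4)nn23)cc(OC)c1OC`: 29300 nM

In a functional assay on DU-145 cells (Homo sapiens) for antiproliferative activity, read by MTT assay, with a stated time of 24 h (a higher number here means a weaker inhibitor, a lower number a stronger inhibitor), compound 1 gives 19500 nM, the lowest of the two numbers; compound 2 gives 29300 nM, and the step of a 1.5-fold higher number from compound 1 to compound 2 (0.18 log units; within the scatter) is within the scatter. Compound 3 `COc1cc(/C=C/C(=O)c2cc(-c3cc(OC)c(OC)c(OC)c3)n3nc(-c4ccccc4)cc3n2)cc(OC)c1OC` carries 3,4,5-trimethoxyphenyl in place of 4-chlorophenyl on a double-bonded chain carbon bound to a double-bonded chain carbon. Among the compounds with values here, no measured step bears on this aryl exchange; the only recorded step is the within-scatter a 1.5-fold higher number from compound 1 to compound 2 (0.18 log units; within the scatter), which concerns the enone orientation. With nothing pointing either way, no step beyond the scatter is expected in this assay. Compound 3 is therefore estimated at 20000 nM, with a range of 7000 nM to 60000 nM, a step of a 1.0-fold higher number from compound 1 to compound 3 (0.01 log units; within the scatter).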

Compound 3, half-maximal inhibitory concentration: 17900 nM
Beside the measured number, compound 3's estimate is 1.1-fold (0.05 log units) above it; the measured number falls inside the stated range.
By their numbers in this assay, from the lowest: compounds 3, 1 and 2 (each within the scatter of the next).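

In this assay the exchange of 4-chlorophenyl for 3,4,5-trimethoxyphenyl on a double-bonded chain carbon bound to a double-bonded chain carbon gives a 1.1-fold lower number from compound 1 to compound 3 (0.04 log units; within the scatter) and so stays within the scatter. This position therefore tolerates an aryl group of 12 heavy atoms with 3 hydrogen-bond acceptors in place of one of 7 heavy atoms with none. No supporting data bear on why the number holds.

Still open, on these data alone, is whether any change at this position gives a step beyond the scatter. An amine, a carboxylic acid or a longer chain in place of the aryl group would test this.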